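The source may report more compounds than this note shows. Statements on the series, on what has been measured and on what is new or still open speak of the compounds shown alone.

In a functional assay on MCF7 cells (Homo sapiens) for cytotoxicity, read by sulforhodamine B assay, with a stated time of 48 h (on this read-out higher numbers stand for weaker inhibition and lower numbers for stronger inhibition), compound 1 `O=C(c1cccnc1)c1ccccc1O` gives 24600 nM and compound 3 `O=C(c1cccnc1)c1cc(Cl)cc(Cl)c1O` gives 29600 nM and so stands within the scatter of compound 1. Compound 2 `C=CCOc1c(Cl)cccc1C(=O)c1cccnc1` returns > 100000 nM as a limit of the assay and not a number. Compound 4 `O=C(c1cccnc1)c1cccc(Cl)c1O` awaits measurement and has hydrogen in place of chloro on an aromatic carbon of compound 3 (hydrogen in place of chloro on an aromatic carbon). The step to compound 4 is expected to stay within the scatter in this assay because compound 1 at 24600 nM carries no chloro at all and still lies within the scatter of compound 3. The estimated change is a 1.1-fold lower number from compound 3 to compound 4 (0.06 log units; within the scatter) and no more than that. For compound 4 the expected value is 26000 nM with an estimated range from 12000 nM to 55000 nM on this reading.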

Compound 4, half-maximal inhibitory concentration: 26700 nM
Compound 4: middle estimate off by 1.0-fold (0.01 log units), on the low side, within the range that was stated.
By their numbers in this assay, from the lowest: compounds 1, 4 and 3 (each within the scatter of the next). At a limit, above all of these: compound 2.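

In this assay the chloro para to a hydroxy group makes no readable difference (a 1.1-fold lower number from compound 3 to compound 4 (0.04 log units; within the scatter)), and the other chloro also stays within the scatter (a 1.1-fold higher number from compound 1 to compound 4 (0.04 log units; within the scatter)), so compounds with none, one or two chloro groups read alike. On the oxygen, hydrogen in place of allyl gives a step beyond the scatter (an at least 3.7-fold lower number from compound 2 to compound 4 (0.57 log units; beyond the scatter)). Among these compounds, that step rests on a limit and not on a number, the one for compound 2: the limit of > 100000 nM in this assay, at which 1 of the 4 values shown sits.

Going by these compounds, whether an amine or a carboxylic acid at the chloro position would shift the value remains open. So does whether a methyl group on the oxygen would behave like allyl or like hydrogen.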